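This account rests on a few compounds, and the source may have more. Where it says the series, first, only, none or still open, it means among the compounds named here.

Compound 1 `Cc1ncnc2c1c(I)cn2[C@@H]1O[C@H](CO)[C@@H](O)[C@H]1O` gives 12200 nM in a functional assay on A549 cells (Homo sapiens), read by MTT assay, with a stated time of 72 h; on this read-out lower numbers stand for stronger inhibition and higher numbers for weaker inhibition.
Compound 2 `CNc1ncnc2c1c(I)cn2[C@@H]1O[C@H](CO)[C@@H](O)[C@H]1O` gives only a limit, > 100000 nM, in this assay.
Compound 3 `COc1ncnc2c1c(I)cn2[C@@H]1O[C@H](CO)[C@@H](O)[C@H]1O` also gives only a limit, > 20000 nM, in this assay.

Compound 2 thus stands at the limit of > 100000 nM in this assay, at which 1 of the 3 values shown sits, with no exact number. The step of an at least 8.1-fold higher number from compound 1 to compound 2 (0.91 log units; beyond the scatter) lies beyond the scatter, whereas an at least 1.6-fold higher number from compound 1 to compound 3 (0.21 log units; that floor lies within the scatter) has a floor within it, and a step that the two limits leave unreadable from compound 2 to compound 3 cannot be read. Compound 4 `CNc1ncnc2c1c(-c1ccco1)cn2[C@@H]1O[C@H](CO)[C@@H](O)[C@H]1O` differs from compound 2 by furan-2-yl in place of iodo on an aromatic carbon. All three measured steps change a group on a different aromatic carbon of the shared core, so none bears on this change, and its size or direction in this assay cannot be read from them. Compound 4 is therefore estimated at 30000 nM, within 3000 nM to 200000 nM, a deliberately wide range. That estimate means an expected step of an at least 3.3-fold lower number from compound 2 to compound 4 (0.52 log units; beyond the scatter).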

Compound 4, half-maximal inhibitory concentration: 2570 nM
Compound 4: middle estimate off by 12-fold (1.07 log units), on the high side, and the stated range ends above it.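

In this assay, the group at this position clearly matters: furan-2-yl in place of iodo, with methylamino unchanged on the shared core, gives an at least 38-fold lower number from compound 2 to compound 4 (1.59 log units; beyond the scatter). The other steps shown all change a different aromatic carbon, so this is the first reading of this position. The value of compound 2 is a limit, so this step has a floor but no exact size: the limit of > 100000 nM in this assay, at which 1 of the 4 values shown sits.

With only iodo and furan-2-yl shown here, it remains open whether another ring, such as phenyl or thiophen-2-yl, would do the same. On these data alone, it also remains open whether furan-2-yl would give a similar step with methyl or methoxy on the core instead of methylamino.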